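This account rests on a few compounds, and the source may have more. Where it says the series, first, only, none or still open, it means among the compounds named here.

Of the compounds shown here, three have been tested in a functional assay on CCRF S-180 cells (Mus musculus); a lower number here means that less compound is needed, a higher number that more compound is needed for the effect. Compound 1 `O=c1ccn([C@@H]2O[C@H](CO)C[C@@H]2O)c(=O)[nH]1` gives > 100 uM, which is a limit of the assay rather than a number. Compound 2 `O=c1ccn([C@@H]2O[C@H](CO)C[C@H]2O)c(=O)[nH]1` gives > 100 uM, again a limit. The two differ only in configuration, and the step that the two limits leave unreadable from compound 1 to compound 2 cannot be read because of the limit of > 100 uM in this assay, at which 2 of the 3 values shown sit. For the measured compounds named here, compound 3 `CC(=O)OC[C@@H]1C[C@H](OC(C)=O)[C@H](n2ccc(N)nc2=O)O1` is the one compound with a number in this assay, giving 30 uM. Going by the values given here, the other two compounds stop at a limit of the assay, so there is no measured step against which compound 3 can be placed.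

Compound 4 `CC(=O)OC[C@@H]1C[C@H](O)[C@H](n2ccc(N)nc2=O)O1` is the next compound to be measured. It differs from compound 3 by hydrogen in place of acetyl on an oxygen on a saturated carbon. Among the compounds with values here, no measured step in this set involves such a change, so no prior step bears on it. Without a guide, the step of a 1.3-fold higher number from compound 3 to compound 4 (0.12 log units; within the scatter) is expected to stay within the usual scatter, and compound 4 is estimated at 40 uM, with a range from 10 uM to 150 uM.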

Compound 4, concentration for half-maximal effect: 13 uM
For compound 4 the middle estimate is 3.1-fold (0.49 log units) above the measured one; the measured number falls inside the stated range.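

For the compounds shown here, this is the first readable step: in this assay, replacing acetoxy with hydroxy gives a 2.3-fold lower number from compound 3 to compound 4 (0.36 log units; beyond the scatter). The step is modest, but it shows that the acetyl on this oxygen on a saturated carbon is not needed for the effect, since the compound with the free hydroxy needs less compound rather than more. Nothing measured here accounts for the direction or size of this step.

As far as these compounds go, whether an amine or a methoxy group at this place would match hydroxy stays open, as does whether a longer acyl chain such as butyryl would behave like acetoxy. From the compounds shown here alone, compound 4 also still carries a second acetyl group, and the effect of replacing that one with hydrogen remains unknown.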